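Compound 3 to compound 4: swapping the triazole substituent

The compounds below may be only part of what the source reports. "The series", "measured", "known", "first", "only" and "open" are said of these compounds alone.

Values so far in a functional assay on HeLa cells (Homo sapiens) for antiproliferative activity, read by MTT assay, with a stated time of 72 h (a lower number here means a stronger inhibitor, a higher number a weaker inhibitor), for three compounds:
- Compound 1 `CCCCCc1ccc(-c2cn(C[C@H](O)[C@H]3OC(=O)C(OCc4ccccc4)=C3OCc3ccccc3)nn2)cc1` gives 8390 nM in this test.
- Compound 2 `COc1ccccc1-c1cn(C[C@H](O)[C@H]2OC(=O)C(OCc3ccccc3)=C2OCc2ccccc2)nn1` gives > 100000 nM as a limit of the assay.
- Compound 3 `O=C1O[C@H]([C@@H](O)Cn2cc(CNS(=O)(=O)c3ccc(F)cc3)nn2)C(OCc2ccccc2)=C1OCc1ccccc1` gives 25000 nM in this test.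

Compound 3 holds the higher of the two true numbers, and the third value is only a limit. The nearest number lies close by, with a 3.0-fold higher number from compound 1 to compound 3 (0.47 log units; beyond the scatter) as the modest gap.

Among the compounds with values here, compound 4 `Cc1ccc(-c2cn(C[C@H](O)[C@H]3OC(=O)C(OCc4ccccc4)=C3OCc3ccccc3)nn2)cc1` carries 4-methylphenyl in place of (((4-fluorophenyl)sulfonyl)amino)methyl on an aromatic carbon as its single change.

Within the data shown here, two measured steps bear on this place. The modest 3.0-fold higher number from compound 1 to compound 3 (0.47 log units; beyond the scatter) favours the aryl group there, whereas the large at least 11-fold higher number from compound 1 to compound 2 (1.07 log units; beyond the scatter) shows that an aryl group alone does not secure activity. These pull in opposite directions, so the step expected in this assay is a 1.4-fold lower number from compound 3 to compound 4 (0.14 log units; within the scatter) and none beyond the scatter is expected.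

The estimated value for compound 4 is 18000 nM with an expected range from 6000 nM to 60000 nM in this test.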

Compound 4, half-maximal inhibitory concentration: 25500 nM
Beside the measured number, compound 4's estimate is 1.4-fold (0.15 log units) below it; low and high end bracket the measured number.
By their numbers in this assay, from the lowest: compound 1; then compounds 3 and 4 (each within the scatter of the next). At a limit, above all of these: compound 2.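

Working notes: in this assay, a 1.0-fold higher number from compound 3 to compound 4 (0.01 log units; within the scatter), so on this aromatic carbon of the ring with 3 nitrogen, the (((4-fluorophenyl)sulfonyl)amino)methyl group and 4-methylphenyl cannot be told apart, even though only the leaving group carries a hydrogen-bond donor and acceptors. Among the aryl groups, the chain on the phenyl ring now has a readable effect, with a 3.0-fold higher number from compound 1 to compound 4 (0.48 log units; beyond the scatter): the 4-pentylphenyl group of compound 1 holds the lower number. The 2-methoxyphenyl comparison rests on a limit of the assay, so an at least 3.9-fold lower number from compound 2 to compound 4 (0.59 log units; beyond the scatter) is a bound only: the limit of > 100000 nM in this assay, at which 1 of the 4 values shown sits.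

On these data alone, only methyl and pentyl chains are compared here, so whether a hexyl or octyl chain would lower the number further stays open. Also open, as far as these compounds go, is how an amine or a carboxylic acid in that place on the phenyl ring would read in this assay.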